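Replacing the acetyl methyl of compound 1 with a chlorophenyl ring

A few compounds are considered here, and "the series" means these few. Any claim that something is new, unique, unknown or untested is made for them only; others in the source may bear on it.

Compound 1: `CC(=O)Nc1c(C(O)(C(F)(F)F)C(F)(F)F)ccc2ccccc12` — 18 nM
Compound 2: `CC(C)CCC(=O)Nc1c(C(O)(C(F)(F)F)C(F)(F)F)ccc2ccccc12` — 49 nM
Compound 3: `O=C(Nc1c(C(O)(C(F)(F)F)C(F)(F)F)ccc2ccccc12)C1CCCC1` — 495 nM

All three compounds share one core, an amide on a naphthalene-type scaffold bearing a hexafluoro-hydroxypropyl group, and differ only in the group on the carbonyl carbon. In an assay on LtK cells with ATP-sensitive inward rectifier potassium channel 11 (Homo sapiens) as the target (on this read-out higher numbers stand for an effect only at larger amounts of compound and lower numbers for an effect already at smaller amounts), compound 1 gives 18 nM, the lowest number of the three; compound 2 gives 49 nM and compound 3 gives 495 nM.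

Compound 4, `O=C(Nc1c(C(O)(C(F)(F)F)C(F)(F)F)ccc2ccccc12)c1ccccc1Cl`, has not yet been measured. It differs from compound 1 in one place: 2-chlorophenyl in place of methyl on a carbonyl carbon. Going by the values given here, two measured steps bear on this. Enlarging the group on the carbonyl carbon from methyl to cyclopentyl gave a 28-fold higher number from compound 1 to compound 3 (1.44 log units; beyond the scatter), and extending the chain gave a 2.7-fold higher number from compound 1 to compound 2 (0.43 log units; beyond the scatter). Both steps point the same way: a larger group on the carbonyl carbon raised the number, and the ring did so more than the open chain. A 2-chlorophenyl group is larger still and ring-shaped, so a higher number is expected, a 17-fold higher number from compound 1 to compound 4 (1.22 log units; beyond the scatter). Compound 4 is therefore estimated at 300 nM, with a range from 60 nM to 1500 nM.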

Compound 4, half-maximal effective concentration: 2040 nM
Estimate against measurement, compound 4: 6.8-fold (0.83 log units) below, outside the stated range (above it).
By their numbers in this assay, from the lowest: compound 1; then compound 2; then compound 3; then compound 4.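

In this assay the 2-chlorophenyl group gives the largest step yet seen on this carbonyl carbon, a 110-fold higher number from compound 1 to compound 4 (2.05 log units; beyond the scatter) and the highest number of the four compounds. It also goes beyond both saturated groups, with a 4.1-fold higher number from compound 3 to compound 4 (0.62 log units; beyond the scatter) when it replaces cyclopentyl and a 42-fold higher number from compound 2 to compound 4 (1.62 log units; beyond the scatter) when it replaces isopentyl, so an aromatic ring carrying chlorine is the least favourable group shown here, while methyl still gives the lowest number. No measurement in hand explains why this change raises the number so steeply.

A plain phenyl group on the same carbonyl carbon would help separate the share of the ring from the share of the chlorine in this rise. From the compounds shown here alone, whether any group can bring the number below that of the methyl compound also remains open, and a small group such as ethyl or methoxy in that place would begin to test it.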